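This account rests on a few compounds, and the source may have more. Where it says the series, first, only, none or still open, it means among the compounds named here.

Notes on the series. The shared core of compound 1 `COc1ccc(-c2cnc3nc(N)nc(NC(C)C)c3n2)cc1OC` carries an isopropylamino group and, in a functional assay on cells (T-cell, Homo sapiens) for inhibition (a higher number here means a weaker inhibitor, a lower number a stronger inhibitor), compound 1 gives 600 nM. Compound 2 `COc1ccc(-c2cnc3nc(N)nc(N4CCN(c5ccc(F)cc5)CC4)c3n2)cc1OC` replaces that group with a 4-fluorophenyl-bearing piperazine, and in this assay compound 2 gives 100 nM, the lower of the two numbers that the assay has produced so far; compound 1 sits higher, and the gap between them is beyond the scatter of repeats. Compound 3 `CCOc1nc(N)nc2ncc(-c3ccc(F)c(F)c3)nc12` is of a different build, with an ethoxy group in place of the amine and a difluorophenyl ring; in this assay compound 3 gives only > 10000 nM, which is a limit of the assay and not a number (the limit of > 10000 nM in this assay, at which 1 of the 3 values shown sits).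

Compound 4 `COc1ccc(-c2cnc3nc(N)nc(N4CCN(C(=O)Nc5ccc(F)cc5)CC4)c3n2)cc1OC` is not yet measured. It differs from compound 2 in one place: (4-fluorophenyl)carbamoyl in place of 4-fluorophenyl on an amine nitrogen in a ring. Among the compounds with values here, no measured pair in the set tracks a change of this kind, so the step has no precedent here. A modest loss is expected, a step of a 3.0-fold higher number from compound 2 to compound 4 (0.48 log units; beyond the scatter) that is expected to remain moderate. For compound 4 in this assay the estimate is 300 nM, with a range from 80 nM to 1500 nM.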

Compound 4, half-maximal inhibitory concentration: 7 nM
Compound 4: the middle estimate sits 43-fold (1.63 log units) above what was measured, outside the stated range (below it).
By their numbers in this assay, from the lowest: compound 4; then compound 2; then compound 1. At a limit, above all of these: compound 3.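

In this assay, the step on the amine nitrogen in a ring is large: a 14-fold lower number from compound 2 to compound 4 (1.15 log units; beyond the scatter). This shows that the group on this nitrogen strongly affects the number, and that the 4-fluorophenyl need not be attached directly for activity to be kept. The (4-fluorophenyl)carbamoyl group keeps the fluorinated aromatic ring and adds a carbonyl and a hydrogen-bond donor, but nothing shown gives a measured reason for the lower number.

Going by these compounds, it remains open whether the carbonyl alone or the carbonyl with the amide hydrogen carries the change. An acetyl group, a carbamate with oxygen in place of the carbamoyl nitrogen, or a chlorine or methoxy group in place of the fluorine would help to separate these parts.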